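A few compounds are considered here, and "the series" means these few. Any claim that something is new, unique, unknown or untested is made for them only; others in the source may bear on it.

Series notes. Compound 1 `CC(C)(C)OC(=O)N[C@@H](C(=O)NNC(=O)c1ccc([N+](=O)[O-])o1)c1ccccc1` carries a carbamate on its core; in a functional assay on MRC5 cells (Homo sapiens) for cytotoxicity (a higher number here means that more compound is tolerated, a lower number that less compound is tolerated), compound 1 gives 6000 nM. Compound 2 `N[C@@H](C(=O)NNC(=O)c1ccc([N+](=O)[O-])o1)c1ccccc1` shows hydrogen in place of tert-butoxycarbonyl on an amine nitrogen and in this assay compound 2 gives 14000 nM, a step of a 2.3-fold higher number from compound 1 to compound 2 (0.37 log units; beyond the scatter). Compound 3 `CC(C)(C)OC(=O)Nc1ccc2cc(C(=O)NNC(=O)c3ccc([N+](=O)[O-])o3)ccc2c1` is built on another core; the difference between the two cores is not broken down here. In this assay compound 3 gives 2000 nM, the lowest of the three numbers. Compound 4 `Nc1ccc2cc(C(=O)NNC(=O)c3ccc([N+](=O)[O-])o3)ccc2c1` is not yet measured and differs from compound 3 by hydrogen in place of tert-butoxycarbonyl on a nitrogen on an aromatic ring. This is the same kind of change as from compound 1 to compound 2, but the place differs: there an amine nitrogen whose other neighbours are saturated chain carbon, here a nitrogen on an aromatic ring whose other neighbours are aromatic carbon. Resting on a 2.3-fold higher number from compound 1 to compound 2 (0.37 log units; beyond the scatter), a step of similar size is expected in this assay, namely a 2.3-fold higher number from compound 3 to compound 4 (0.36 log units; beyond the scatter). Compound 4 is therefore estimated at 4600 nM, with a range of 2300 nM to 9500 nM kept wide as the place of the change is not the same.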

Compound 4, half-maximal cytotoxic concentration: 770 nM
Compound 4: middle estimate off by 6.0-fold (0.78 log units), on the high side; the measured number lies below the stated range.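

In this assay, the loss of tert-butoxycarbonyl from a nitrogen on an aromatic ring gives a 2.6-fold lower number from compound 3 to compound 4 (0.41 log units; beyond the scatter). The same change therefore moves the number in opposite directions on the two cores: the same change on two cores in this assay, a 2.3-fold higher number (0.37 log units; beyond the scatter) from compound 1 to compound 2 and a 2.6-fold lower number (0.41 log units; beyond the scatter) from compound 3 to compound 4, 6.1-fold (0.78 log units) apart, beyond the scatter of two such steps

A step read on one core thus cannot be carried to the other in this series. What sets the two results apart remains unshown: the core and the kind of nitrogen differ together, and each direction rests on a single pair.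

From the compounds shown here alone, it remains open whether an acetyl or methyl group in place of tert-butoxycarbonyl would follow the same opposite directions on these two cores. Also open, going by these compounds, is how a carboxylic acid on either core would read in this assay.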